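Working notes: compound 2 to compound 4 in growth inhibition

The source may hold more compounds than are shown below. What is called first, only, known or untested is meant among the compounds shown, and "the series" means these compounds.

Of the compounds shown here, three have so far been tested in a functional assay on HepG2 cells (Homo sapiens) for inhibition, read by MTT assay, with a stated time of 72 h, tested at 30 uM; a lower number here means less inhibition of growth, a higher number more inhibition of growth at the concentration tested. Compound 1 `C=CCc1ccc(OCc2cn(-c3ccccc3CO)nn2)c(O)c1` gives 4.2%. Compound 2 `C=CCc1cc(O)c(O)c(CN2CCC(CO)CC2)c1` gives 4.7%. Compound 3 `C=CCc1ccc(OCc2cn(-c3cc(OC)c(OC)c(OC)c3)nn2)c(O)c1` gives 1.2%. Compound 2 holds the highest of the three numbers, yet its gap to compound 1 and its gap to compound 3 both fall within the scatter, so the three results cannot be told apart. No two of these compounds differ in one place only, so no single structural step can be read from the measured set.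

Compound 4 `C=CCc1cc(O)c(O)c(CN2CCC(Cc3ccccc3)CC2)c1` is still to be measured. Against compound 2 the change is phenyl in place of hydroxy on a saturated chain carbon bound to a saturated ring carbon. For the measured compounds named here, nothing among the measured compounds shows how a change of this kind moves the number; all three measured values sit near the bottom of the scale. The expected step is a number 3.3 percentage points higher from compound 2 to compound 4 (within the scatter), upward but not clearly beyond the scatter. Compound 4 is estimated at 8%, with a range from 0% to 22%.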

Compound 4, percent growth inhibition at one concentration: 70.2%
The estimate for compound 4 lay 62.2 percentage points below the measured number; the measured number lies above the stated range.
By their numbers in this assay, from the lowest: compounds 3, 1 and 2 (each within the scatter of the next); then compound 4.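

In this assay, for the compounds shown here, phenyl in place of hydroxy on a saturated chain carbon bound to a saturated ring carbon gives a number 65.5 percentage points higher from compound 2 to compound 4 (beyond the scatter), the only step that can be read so far. The earlier compounds shown here all lie within the scatter of one another and gave no sign that this number could be moved, whereas this position shows that it can, with the same difference reading hydroxymethyl to benzyl when cut one bond further out. No measurement here bears on why the number rises.

The compounds shown do not tell whether the step needs the phenyl ring or only the loss of the hydroxy, nor how cyclohexyl, an amine or a longer chain would read at this place. They also leave open whether benzyl would give a comparable step on the core of compound 1.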